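The compounds below may be only part of what the source reports. "The series", "measured", "known", "first", "only" and "open" are said of these compounds alone.

Compound 1 `Cc1cnc(C(=O)Nc2cc(Cl)cc3cccnc23)cn1` and compound 2 `O=C(Nc1cc(Cl)cc2cccnc12)c1ncccn1` are built on one core, while compound 3 `Cc1cnc(C(=O)Nc2cc(OCCC3CCN(C(=O)OC(C)(C)C)CC3)cc3cccnc23)cn1` and compound 4 `CC(C)(C)OC(=O)N1CCC(CCOc2cc(NC(=O)c3ncccn3)c3ncccc3c2)CC1` are built on another; how the two cores differ is not broken down here. In a functional assay on PANC-1 cells (Homo sapiens) for inhibition, read by MTT assay, with a stated time of 72 h (on this read-out lower numbers stand for stronger inhibition and higher numbers for weaker inhibition), compound 1 gives 1770 nM. Compound 2 carries the change (pyrimidin-2-yl in place of 5-methylpyrazin-2-yl on a carbonyl carbon), and in this assay compound 2 gives 4670 nM, which amounts to a 2.6-fold higher number from compound 1 to compound 2 (0.42 log units; beyond the scatter). Compound 3 gives 9670 nM in this assay, the highest number among the three measured compounds; its nearest neighbour is compound 2 and the furthest is compound 1, each lower by more than the scatter.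

Compound 4 has not yet been measured. It differs from compound 3 by pyrimidin-2-yl in place of 5-methylpyrazin-2-yl on a carbonyl carbon, the same change that turns compound 1 into compound 2; among the compounds shown this change occurs twice, and the place where it is made reads the same in both pairs. Among the compounds with values here, for compound 4 a step of about the same size is expected, a 2.5-fold higher number from compound 3 to compound 4 (0.39 log units; beyond the scatter), resting on the step of a 2.6-fold higher number from compound 1 to compound 2 (0.42 log units; beyond the scatter), the only measured instance of this change. Compound 4 is therefore estimated at 24000 nM in this assay, with the expected range running from 9000 nM to 60000 nM, and with some chance that the read-out returns only a limit rather than a number.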

Compound 4, half-maximal inhibitory concentration: > 10000 nM
Compound 4: only a limit was reported; the forecaster's own chance of this, stated with the estimate: 20%; the middle value lies beyond the limit too.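

In this assay compound 4 gives > 10000 nM, which is a limit of the assay and not a number. Read as a step, pyrimidin-2-yl in place of 5-methylpyrazin-2-yl on a carbonyl carbon therefore yields only a floor, an at least 1.0-fold higher number from compound 3 to compound 4 (0.01 log units; that floor lies within the scatter), and that floor alone does not show that the change has any effect on the core of compound 3. The result does not show a step in the opposite direction, but neither does it establish that the change carries over from the core of compound 1 to the core of compound 3 with the same size: the same change on two cores in this assay, a 2.6-fold higher number (0.42 log units; beyond the scatter) from compound 1 to compound 2 and an at least 1.0-fold higher number (0.01 log units; that floor lies within the scatter) from compound 3 to compound 4; the limit leaves it open whether they differ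

The compounds shown leave open how large the step is when both partners give numbers clear of the limit, as might be tested on a pair carrying a free amine or a shorter chain in place of the side chain of compound 3. They also leave open whether the methyl group or the ring nitrogen arrangement accounts for the step, a question that a plain pyrazin-2-yl group on the same carbonyl carbon could help to separate.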